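Piperidine aryl swap in the dopamine receptor amide series

The source may hold more compounds than are shown below. What is called first, only, known or untested is meant among the compounds shown, and "the series" means these compounds.

Compound 1 `COc1ccccc1C1CCN(CC(=O)Nc2cccc(C)c2)CC1` gives 420 nM in a functional assay on HEK293 cells for agonist activity at D(4) dopamine receptor (Homo sapiens), read by FLIPR (a higher number here means that more compound is needed for the effect, a lower number that less compound is needed), the highest of the three numbers measured. Compound 2 `Cc1cc(C)cc(NC(=O)CN2CCC(c3cccc[n+]3[O-])CC2)c1` gives 52 nM and compound 3 `Cc1cc(NC(=O)CN2CCC(c3cccc[n+]3[O-])CC2)ccc1F` gives 18 nM in this assay; both carry a different group on the saturated ring carbon than compound 1. Compound 4 `Cc1cccc(NC(=O)CN2CCC(c3ccc(O)cc3)CC2)c1` is compound 1 with 4-hydroxyphenyl in place of 2-methoxyphenyl on a saturated ring carbon. Within the data shown here, the only measured step, a 2.9-fold lower number from compound 2 to compound 3 (0.46 log units; beyond the scatter), concerns the amide-type nitrogen, not the saturated ring carbon, so no measured step bears directly on the change to compound 4. Without a comparable step, the expectation for compound 4 is a change of about a 1.4-fold lower number from compound 1 to compound 4 (0.15 log units; within the scatter), with no confident direction. Compound 4 is therefore estimated at 300 nM, between 70 nM and 1300 nM.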

Compound 4, half-maximal effective concentration: 70 nM
Compound 4: the middle estimate sits 4.3-fold (0.63 log units) above what was measured, within the range that was stated.
By their numbers in this assay, from the lowest: compound 3; then compounds 2 and 4 (each within the scatter of the next); then compound 1.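

In this assay, among these compounds, the saturated ring carbon proves responsive: 4-hydroxyphenyl in place of 2-methoxyphenyl gives a 6.0-fold lower number from compound 1 to compound 4 (0.78 log units; beyond the scatter) on the core of compound 1, the first step at this position and one beyond the scatter. This step swaps the oxygen substituent and its ring position together, so the contribution of each remains unresolved.

A 4-methoxyphenyl or 2-hydroxyphenyl group on the same carbon would separate the two. No measured evidence accounts for the size of this step.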